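Swapping a Side Chain on a Purine Nitrogen

This account rests on a few compounds, and the source may have more. Where it says the series, first, only, none or still open, it means among the compounds named here.

Of the compounds shown here, three built around the same core have been tested for their power to hold back the growth of lung cancer cells. Compound 1 `CCC(C)n1cnc2c(NCc3ccc(C(=O)Nc4ccccc4N)cc3)nc(Cl)nc21` gives 67.7% in a functional assay on NCI-H460 cells (Homo sapiens) for antiproliferative activity, read by CCK-8 assay, with a stated time of 72 h, tested at 8 uM; on this read-out higher numbers stand for a stronger effect at the one concentration tested and lower numbers for a weaker effect; this is the highest of the three numbers, yet both neighbours lie within the usual scatter of it. Compound 2 `Nc1ccccc1NC(=O)c1ccc(Cn2cnc3c(NCc4ccccc4)nc(Cl)nc32)cc1` gives 61.2% in this assay, and compound 3 `Nc1ccccc1NC(=O)/C=C/c1ccc(Cn2cnc3c(Nc4cccc(OC(F)(F)F)c4)nc(Cl)nc32)cc1` gives 66.7%. Compound 4 `Nc1ccccc1NC(=O)c1ccc(CNc2nc(Cl)nc3c2ncn3C2CCCC2)cc1` has not been measured. It differs from compound 1 in one place: cyclopentyl in place of sec-butyl on an aromatic nitrogen. Going by the values given here, no pair of measured compounds shows the effect of such a change, so no size of step is known. The change is expected to leave the number nearly unchanged, a step of a number 0.7 percentage points lower from compound 1 to compound 4 (within the scatter). Compound 4 is therefore estimated at 67%, between 55% and 78%.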

Compound 4, a percentage reported as inhibition, at one concentration (the size of the read-out at that concentration, not a potency): 57.4%
Compound 4: middle estimate off by 9.6 percentage points, on the high side; measured number inside the range.
By their numbers in this assay, from the lowest: compounds 4, 2, 3 and 1 (each within the scatter of the next, the first and the last beyond it).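

Going by these compounds alone, this is the first measured change on this aromatic nitrogen: in this assay, cyclopentyl in place of sec-butyl gives a number 10.3 percentage points lower from compound 1 to compound 4 (beyond the scatter). The step is modest, but it shows that the number responds to the group here, even though both groups are carbon only. Nothing measured here explains the drop.

From the compounds shown here alone, whether the ring or the extra carbon matters stays open; cyclopropyl, cyclohexyl or a longer open chain such as pentyl on this nitrogen could separate the two. This single pair also leaves open whether the step holds with other groups elsewhere on the core.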